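The source may hold more compounds than are shown below. What is called first, only, known or untested is meant among the compounds shown, and "the series" means these compounds.

Compound 1 `C=C(CC)C(=O)c1ccc(OCC(=O)Nc2ccc(C(=O)O)cn2)c(Cl)c1Cl`: 14900 nM
Compound 2 `C=C(CC)C(=O)c1ccc(OCC(=O)Nc2ccc(O)c([N+](=O)[O-])c2)c(Cl)c1Cl`: 7400 nM
Compound 3 `C=C(CC)C(=O)c1ccc(OCC(=O)Nc2ccc3c(c2)C(=O)NC3=O)c(Cl)c1Cl`: 2500 nM

In a functional assay on CLL cells (Homo sapiens) for cytotoxicity, read by MTT assay, with a stated time of 48 h (on this read-out higher numbers stand for an effect only at larger amounts of compound and lower numbers for an effect already at smaller amounts), compound 1 gives 14900 nM. This places it at the upper end of the numbers shown, together with compound 2 at 7400 nM, as these two values lie within the scatter of each other. Compound 3, at 2500 nM, has a lower number than compound 1, and that gap lies beyond the scatter, so compound 3 acts at smaller amounts.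

The next compound to be tested is compound 4 `C=C(CC)C(=O)c1ccc(OCC(=O)Nc2ccc3nc[nH]c3c2)c(Cl)c1Cl`. It keeps the core of compound 1 but carries 1H-benzimidazol-6-yl in place of 5-carboxypyridin-2-yl on an amide-type nitrogen.

For the measured compounds named here, no measured step isolates this exact change, so the expectation in this assay rests on little. Compound 3, at 2500 nM, suggests that replacing the 5-carboxypyridin-2-yl group can lower the number. Compound 2, at 7400 nM, goes against this, as it stays within the scatter of compound 1. The expected step is therefore modest and towards a lower number: a 3.7-fold lower number from compound 1 to compound 4 (0.57 log units; beyond the scatter). The estimate for compound 4 is 4000 nM, with an expected range from 1500 nM to 11000 nM.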

Compound 4, half-maximal effective concentration: 3200 nM
Compound 4: the middle estimate sits 1.3-fold (0.10 log units) above what was measured, and the stated range covers the measured number.
By their numbers in this assay, from the lowest: compounds 3 and 4 (each within the scatter of the next); then compounds 2 and 1 (each within the scatter of the next).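

In this assay, for the compounds shown here, the step of a 4.7-fold lower number from compound 1 to compound 4 (0.67 log units; beyond the scatter) gives the first measured change at this position, on the amide-type nitrogen. It shows that 5-carboxypyridin-2-yl can be exchanged for 1H-benzimidazol-6-yl, a group with the same count of heavy atoms but with two aromatic rings and no oxygen, and that the compound then acts at smaller amounts, by a margin beyond the scatter. Compound 4 at 3200 nM also lies within the scatter of compound 3 at 2500 nM, so two different groups here reach a similar level, while compound 2 stays within the scatter of compound 1, and no information on why the number falls is available.

The compounds shown do not separate what the exchange combines: the loss of the carboxylic acid, the change of ring nitrogens and the added five-membered ring. As far as these compounds go, a plain pyridin-2-yl group or a phenyl group carrying a carboxylic acid on the same nitrogen would help tell these apart, and whether any of this holds outside this assay stays open.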